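A few compounds are considered here, and "the series" means these few. Any claim that something is new, unique, unknown or untested is made for them only; others in the source may bear on it.

Measured in a functional assay on A549 cells (Homo sapiens) for inhibition, read by sulforhodamine B assay, with a stated time of 48 h; a lower number here means a stronger inhibitor of growth, a higher number a weaker inhibitor of growth:
- compound 1 `COC(=O)[C@@]1(C)CCC=C2[C@@H]1CC[C@@H](C)[C@]2(C)Cc1c[nH]c2ccc(F)cc12` gives 6200 nM
- compound 2 `COC(=O)[C@@]1(C)CCC=C2[C@@H]1CC[C@@H](C)[C@]2(C)Cc1c[nH]c2ccc(OC)cc12` gives 2200 nM
- compound 3 `COC(=O)[C@@]1(C)CCC=C2[C@@H]1CC[C@@H](C)[C@]2(C)Cc1c(C)[nH]c2ccc(F)cc12` gives 15000 nM

Compound 2 differs from compound 1 by methoxy in place of fluoro on an aromatic carbon; that change made the step of a 2.8-fold lower number from compound 1 to compound 2 (0.45 log units; beyond the scatter). Compound 3 differs from compound 1 by methyl in place of hydrogen on an aromatic carbon; that change made the step of a 2.4-fold higher number from compound 1 to compound 3 (0.38 log units; beyond the scatter), and compound 3 holds the highest number of the three. Compound 4 `COC(=O)[C@@]1(C)CCC=C2[C@@H]1CC[C@@H](C)[C@]2(C)Cc1c(C)[nH]c2ccc(OC)cc12` is not yet measured. It differs from compound 3 by methoxy in place of fluoro on an aromatic carbon, the same change as from compound 1 to compound 2, made on the core of compound 3. On that single earlier step, a similar step is expected here: a 2.7-fold lower number from compound 3 to compound 4 (0.44 log units; beyond the scatter), resting on compound 1 and compound 2 showing a 2.8-fold lower number from compound 1 to compound 2 (0.45 log units; beyond the scatter). For compound 4 in this assay the estimate is 5500 nM, expected between 2500 nM and 12000 nM.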

Compound 4, concentration for 50% growth inhibition: 16000 nM
Compound 4: middle estimate off by 2.9-fold (0.46 log units), on the low side; measured number outside the range, above it.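

The swap of methoxy for fluoro gives a 1.1-fold higher number from compound 3 to compound 4 (0.03 log units; within the scatter), so in this assay the lower number seen on the core of compound 1 does not carry over to the core of compound 3: the same change on two cores in this assay, a 2.8-fold lower number (0.45 log units; beyond the scatter) from compound 1 to compound 2 and a 1.1-fold higher number (0.03 log units; within the scatter) from compound 3 to compound 4, 3.0-fold (0.48 log units) apart, beyond the scatter of two such steps

Read the other way, methyl in place of hydrogen gives a 7.3-fold higher number from compound 2 to compound 4 (0.86 log units; beyond the scatter), so the two changes do not act independently of each other in these compounds: the same change on two cores in this assay, a 2.4-fold higher number (0.38 log units; beyond the scatter) from compound 1 to compound 3 and a 7.3-fold higher number (0.86 log units; beyond the scatter) from compound 2 to compound 4, 3.0-fold (0.48 log units) apart, beyond the scatter of two such steps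

Among these compounds, this rests on only two pairs of steps in one cell assay, and it shows that the size of each step depends on the core, not what lies behind that dependence.

The compounds shown leave open whether the same dependence holds for other groups on that aromatic carbon, such as chloro or hydroxy, or for a longer chain, such as ethyl, in place of the added methyl. Also open, on these data alone, is how the pattern behaves if the methyl ester gives way to a carboxylic acid or an amide.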